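A Second Chloro Added to the Core of Compound 2

The source may report more compounds than this note shows. Statements on the series, on what has been measured and on what is new or still open speak of the compounds shown alone.

Of the compounds shown here, three have been measured in a functional assay on lung (Cavia porcellus) for binding affinity to cysteinyl leukotriene receptor (Homo sapiens); a higher number here means a weaker inhibitor, a lower number a stronger inhibitor. Compound 1 `C/C(=C/c1ccc2ccc(Cl)cc2n1)c1cccc(OC(C)C(=O)O)c1` gives 495 nM, compound 2 `O=C(O)CCCOc1cccc(/C=C/c2ccc3cc(Cl)ccc3n2)c1` gives 270 nM, and compound 3 `Oc1cccc(/C=C/c2ccc3ccccc3n2)c1` gives 560 nM. Compound 2 holds the lowest of the three numbers; its gap to compound 1 lies within the scatter, while its gap to compound 3 lies beyond it. Compound 4 `O=C(O)CCCOc1cccc(/C=C/c2ccc3cc(Cl)c(Cl)cc3n2)c1` differs from compound 2 by a single change, (chloro in place of hydrogen on an aromatic carbon). Going by the values given here, no step between measured compounds shows the effect of such a change, so the expectation rests on compound 2 alone. The step expected is a 1.1-fold lower number from compound 2 to compound 4 (0.03 log units; within the scatter). In this assay compound 4 is expected to give about 250 nM, within a range from 100 nM to 650 nM.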

Compound 4, half-maximal inhibitory concentration: 54 nM
Estimate against measurement, compound 4: 4.6-fold (0.67 log units) above, outside the stated range (below it).
By their numbers in this assay, from the lowest: compound 4; then compounds 2, 1 and 3 (each within the scatter of the next, the first and the last beyond it).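

In this assay chloro in place of hydrogen on an aromatic carbon, ortho to a chloro group, brings a 5.0-fold lower number from compound 2 to compound 4 (0.70 log units; beyond the scatter) and this step lies beyond the scatter. Going by these compounds alone, the earlier compounds held no step of any kind, so this is the first sign that this position on the shared core responds to a change. No measurement shown explains the gain. The compounds shown do not tell whether fluoro, methyl or methoxy at this place would give a similar step, nor whether a chloro here would do so without the chloro group ortho to it.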